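A few compounds are considered here, and "the series" means these few. Any claim that something is new, unique, unknown or untested is made for them only; others in the source may bear on it.

Compound 1 `CC(C)C1C(=O)N(C)c2cnc(Nc3ccc(S(N)(=O)=O)cc3)nc2N1C` gives 254 nM in an assay on Sf9 cells for inhibition of serine/threonine-protein kinase 4 (Homo sapiens), read by luminescence and ADP-Glo, with a stated time of 1 h, in the presence of a further agent that is not named here; on this read-out higher numbers stand for weaker inhibition and lower numbers for stronger inhibition; compound 2 `CN1C(=O)C(c2cccc(F)c2)N(C)c2nc(Nc3ccc(S(N)(=O)=O)cc3)ncc21` gives 134 nM; compound 3 `CN1C(=O)C(c2ccccc2C(F)(F)F)N(C)c2nc(Nc3ccc(S(N)(=O)=O)cc3)ncc21` gives 56 nM.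

Compound 3 has the lowest number of the three, and both of its steps lie beyond the scatter, so it is the strongest inhibitor here. Compound 4 `CN1C(=O)C(Cc2ccccc2)N(C)c2nc(Nc3ccc(S(N)(=O)=O)cc3)ncc21` differs from it in one place: benzyl in place of 2-(trifluoromethyl)phenyl on a saturated ring carbon. Every measured step concerns that same ring carbon: a 4.5-fold lower number from compound 1 to compound 3 (0.66 log units; beyond the scatter) and a 2.4-fold lower number from compound 2 to compound 3 (0.38 log units; beyond the scatter), while a 1.9-fold lower number from compound 1 to compound 2 (0.28 log units; within the scatter). Within the data shown here, no measured compound carries a benzyl, so the step to compound 4 is uncertain; since each aromatic ring on that carbon gave lower numbers than isopropyl, the expectation is a modest rise, a 2.7-fold higher number from compound 3 to compound 4 (0.43 log units; beyond the scatter), within the scatter. Compound 4 is estimated at 150 nM, between 50 nM and 450 nM.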

Compound 4, half-maximal inhibitory concentration: > 10000 nM
Compound 4: no number, only a limit; the forecaster's own chance of this, stated with the estimate: 3%; middle value at least 66-fold (1.82 log units) from the limit.
By their numbers in this assay, from the lowest: compound 3; then compounds 2 and 1 (each within the scatter of the next). At a limit, above all of these: compound 4.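

For compound 4 the result is a limit, not a number: the limit of > 10000 nM in this assay, at which 1 of the 4 values shown sits. At this saturated ring carbon the change is large whichever group benzyl replaces: an at least 170-fold higher number from compound 3 to compound 4 (2.25 log units; beyond the scatter), an at least 74-fold higher number from compound 2 to compound 4 (1.87 log units; beyond the scatter) and an at least 39-fold higher number from compound 1 to compound 4 (1.59 log units; beyond the scatter). The earlier steps shown here here were modest at most, so this position tolerates some groups far better than others, and carrying an aromatic ring is not enough, as benzyl has one too. Still open, as far as these compounds go, is whether an unsubstituted phenyl, a 2-phenylethyl chain or a benzyl bearing an amine would behave like compound 3 or like compound 4.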